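The compounds below may be only part of what the source reports. "The series", "measured", "known", "first", "only" and "open" are said of these compounds alone.

Measured so far in a functional assay on the whole organism with Rattus norvegicus as the target, read by paw edema, with a stated time of 3 h, at a dose of 100 mg/kg by the oral route; a higher number here means more inhibition at the dose given (going by the name of the read-out), a lower number less inhibition:

compound 1 `Cc1cccc(-c2nc3ccccc3[nH]2)n1`: 44%
compound 2 `CCc1ccc(-c2nc3ccccc3[nH]2)nc1`: 44%
compound 3 `CCOC(=O)c1cccc(-c2nc3ccccc3[nH]2)n1`: 31%

Compound 3 stands lowest of the three; compound 1 and compound 2 both lie higher by more than the scatter. For the measured compounds named here, the one measured step that touches compound 3 is a number 13 percentage points lower from compound 1 to compound 3 (beyond the scatter), where ethoxycarbonyl replaced methyl on an aromatic carbon.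

Compound 4 `NC(=O)c1cccc(-c2nc3ccccc3[nH]2)n1` differs from compound 3 by amino in place of ethoxy on a carbonyl carbon. Going by the values given here, no measured step exchanges an ethoxy for an amino, so the direction of the change is open. Among the compounds with values here, the only comparison shows that the ethoxycarbonyl of compound 3 sits below the methyl of compound 1, which leaves room either way. Compound 4 is therefore expected to differ little, with a step of a number 7 percentage points higher from compound 3 to compound 4 (within the scatter) in this assay, and its estimate is 38%, ranging from 20% to 55%.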

Compound 4, a percentage reported as inhibition, in the whole organism at one dose (the size of the read-out at that dose, not a potency): 13%
Estimate against measurement, compound 4: 25 percentage points above, outside the stated range (below it).
By their numbers in this assay, from the lowest: compound 4; then compound 3; then compounds 1 and 2 (each within the scatter of the next).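

In this assay the group on the carbonyl carbon matters, not only the carbonyl itself: amino in place of ethoxy gives a number 18 percentage points lower from compound 3 to compound 4 (beyond the scatter). Carbamoyl in place of methyl on the aromatic carbon gives a number 31 percentage points lower from compound 1 to compound 4 (beyond the scatter), so among methyl, ethoxycarbonyl and carbamoyl, carbamoyl gives the least inhibition. Nothing available offers a reason for this fall. On these data alone, it remains open whether a carboxylic acid or a methylamino group on the same carbonyl carbon would sit nearer compound 3 or compound 4.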